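The compounds below may be only part of what the source reports. "The series", "measured", "known", "first", "only" and "open" are said of these compounds alone.

Within the data shown here, in a functional assay on the whole organism for antagonist activity, with Mus musculus as the target (on this read-out higher numbers stand for an effect only at larger amounts of compound and lower numbers for an effect already at smaller amounts), compound 1 `CCC(=O)N(c1ccc(Cl)c(Cl)c1)C1CCCC1N` gives 0.8 mg/kg and compound 2 `CCC(=O)N(c1ccc(Cl)c(Cl)c1)C1CCCC1N(C)CCN(C)C` gives 5 mg/kg, the higher of the two numbers so far. Compound 3 `CCC(=O)N(c1ccc(Cl)c(Cl)c1)C1CCCC1N(C)CCCN(C)C` differs from compound 2 by (dimethylamino)methyl in place of dimethylamino on a saturated chain carbon, two bonds along the chain from an amine nitrogen, which lengthens 2-(dimethylamino)ethyl to 3-(dimethylamino)propyl. Among the measured compounds shown here, the only measured step, a 6.3-fold higher number from compound 1 to compound 2 (0.80 log units; beyond the scatter), replaced amino with the whole (2-(dimethylamino)ethyl)(methyl)amino group, a much larger change than this one. Only a small shift is therefore expected, with no direction favoured and nothing beyond the scatter: no change at the digits printed from compound 2 to compound 3 (within the scatter). For compound 3 the estimated value is 5 mg/kg, with an expected range of 1.5 mg/kg to 15 mg/kg.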

Compound 3, dose for half-maximal effect: 10 mg/kg
Beside the measured number, compound 3's estimate is 2.0-fold (0.30 log units) below it, within the range that was stated.
By their numbers in this assay, from the lowest: compound 1; then compounds 2 and 3 (each within the scatter of the next).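

Going from 2-(dimethylamino)ethyl to 3-(dimethylamino)propyl gives a 2.0-fold higher number from compound 2 to compound 3 (0.30 log units; within the scatter) in this assay, so these two chain lengths cannot be told apart on this read-out. Replacing amino with the whole (3-(dimethylamino)propyl)(methyl)amino group gives a 13-fold higher number from compound 1 to compound 3 (1.10 log units; beyond the scatter), a large step that is clearly beyond the scatter. No measurement here explains these numbers. On these data alone, whether a longer chain such as 4-(dimethylamino)butyl would also match these two compounds remains open. So does the effect of a carboxylic acid in place of the terminal dimethylamino group.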